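Swapping the amine on the shared core

The source may hold more compounds than are shown below. What is called first, only, known or untested is meant among the compounds shown, and "the series" means these compounds.

- compound 1 `COc1cc(Oc2cccc(Nc3ccccc3)c2)cc(OC)c1CNCCNC(C)=O`: 18200 nM
- compound 2 `COc1cc(Oc2cccc(Nc3ccccc3)c2)cc(OC)c1CNCc1ccc(C)cc1`: 13800 nM
- compound 3 `CCN1CCN(Cc2c(OC)cc(Oc3cccc(Nc4ccccc4)c3)cc2OC)CC1`: > 20000 nM (a limit, not a number)

All three results come from a functional assay on HCT-116 cells (Homo sapiens) for inhibition, read by MTT assay, with a stated time of 72 h; on this read-out lower numbers stand for stronger inhibition and higher numbers for weaker inhibition. Compound 3 stands at the limit of > 20000 nM in this assay, at which 1 of the 3 values shown sits, so it has a limit and no exact number.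

Compound 4 `COc1cc(Oc2cccc(Nc3ccccc3)c2)cc(OC)c1CN(C)C` has not yet been measured. It keeps the core of compound 3 and differs in one place: dimethylamino in place of 4-ethylpiperazin-1-yl on a saturated chain carbon bound to an aromatic carbon. In words, it has dimethylamino in place of 4-ethylpiperazin-1-yl on a saturated chain carbon bound to an aromatic carbon.

Three measured steps change the amine at this part of the molecule. The first is a 1.3-fold lower number from compound 1 to compound 2 (0.12 log units; within the scatter). The other two reach the 4-ethylpiperazin-1-yl group: an at least 1.0-fold higher number from compound 1 to compound 3 (0.04 log units; that floor lies within the scatter) and an at least 1.4-fold higher number from compound 2 to compound 3 (0.16 log units; that floor lies within the scatter). Those two are only lower bounds on the true size of the step, but none of the three shows a change beyond the scatter. On that small evidence, a modest shift towards the values of the two measured amines is expected, with no real change beyond the scatter. The expected step is an at least 1.2-fold lower number from compound 3 to compound 4 (0.09 log units; that floor lies within the scatter). Compound 4 is estimated at 16000 nM, with an expected range from 8000 nM to 30000 nM.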

Compound 4, half-maximal inhibitory concentration: 12900 nM
Beside the measured number, compound 4's estimate is 1.2-fold (0.09 log units) above it, and the stated range covers the measured number.
By their numbers in this assay, from the lowest: compounds 4, 2 and 1 (each within the scatter of the next). At a limit, above all of these: compound 3.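

With dimethylamino, which has no ring and fewer heavy atoms than the 4-ethylpiperazin-1-yl group it replaces, the shared core gives an exact reading in this assay, and the step to it is an at least 1.5-fold lower number from compound 3 to compound 4 (0.19 log units; that floor lies within the scatter). The other two steps are a 1.1-fold lower number from compound 2 to compound 4 (0.03 log units; within the scatter) and a 1.4-fold lower number from compound 1 to compound 4 (0.15 log units; within the scatter), so a much smaller amine on this saturated chain carbon cannot be told apart from (4-methylbenzyl)amino or (2-acetamidoethyl)amino, and three quite different groups now give readings within the scatter of one another. Compound 3 still has a limit and not a number: the limit of > 20000 nM in this assay, at which 1 of the 4 values shown sits.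

As far as these compounds go, how far the true value of compound 3 lies past that limit stays open, and with it whether the 4-ethylpiperazin-1-yl group really differs from the other three amines, since the floor of its step lies within the scatter. Also open, from the compounds shown here alone, is whether any other group at this place, such as a primary amine, a morpholine or a carboxylic acid, would move the number beyond the scatter at all.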